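The source may hold more compounds than are shown below. What is called first, only, known or untested is meant among the compounds shown, and "the series" means these compounds.

Compound 1 `Clc1cc(Cl)cc(CO[C@H]2CCCN(Cc3ncco3)[C@H]2c2ccccc2)c1` is one of three compounds examined in an assay on isolated protein for activation of cGMP-dependent protein kinase 1 (Homo sapiens), read by ADP-Glo, with stated times of 120 min and 40 min; a higher number here means that more compound is needed for the effect, a lower number that less compound is needed. For compound 1 the assay returns a limit rather than a number, > 200000 nM, so its true position is not known; this is the limit of > 200000 nM in this assay, at which 1 of the 3 values shown sits. Compound 2 `OC[C@@H](O[C@H]1CCCN(Cc2ncc[nH]2)[C@H]1c1ccccc1)c1cc(Cl)cc(Cl)c1` gives 7000 nM in this assay. Compound 3 `COC(=O)Nn1c(C[C@H]2CCC[C@H](OCc3cc(C(F)(F)F)cc(C(F)(F)F)c3)[C@@H]2c2ccccc2)n[nH]c1=O` gives 4500 nM in this assay. Compound 4 `Cn1ccnc1CN1CCC[C@H](OCc2cc(Cl)cc(Cl)c2)[C@@H]1c1ccccc1` is the untested partner of compound 1, from which it differs in one place: 1-methyl-1H-imidazol-2-yl in place of 1,3-oxazol-2-yl on a saturated chain carbon bound to an amine nitrogen in a ring. For the measured compounds named here, no measured pair shows this change, so its size is open. Compound 4 is expected to need less compound than the limit of compound 1, with the expected step from compound 1 to compound 4 being an at least 2.0-fold lower number from compound 1 to compound 4 (0.30 log units; that floor lies within the scatter). Compound 4 is estimated at 100000 nM, within a range of 10000 nM to 300000 nM.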

Compound 4, half-maximal effective concentration: 165000 nM
Compound 4: middle estimate off by 1.7-fold (0.22 log units), on the low side; low and high end bracket the measured number.
By their numbers in this assay, from the lowest: compounds 3 and 2 (each within the scatter of the next); then compound 4. At a limit, above all of these: compound 1.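

In this assay, for the compounds shown here, 1-methyl-1H-imidazol-2-yl in place of 1,3-oxazol-2-yl gives the first readable pair at this place, with an at least 1.2-fold lower number from compound 1 to compound 4 (0.08 log units; that floor lies within the scatter). Compound 4 gives a measured number, 165000 nM, so this side of the pair is now fixed. The true size of the step stays unknown because the other side of the pair is a limit: the limit of > 200000 nM in this assay, at which 1 of the 4 values shown sits.

As far as these compounds go, whether the change exceeds the usual scatter remains open. So does the effect of a pyridin-2-yl ring or a primary amine on the same saturated chain carbon.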